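The compounds below may be only part of what the source reports. "The series", "measured", "known", "first", "only" and "open" are said of these compounds alone.

Series values in a functional assay on U-937 cells (Homo sapiens) for cytotoxicity, read by MTT assay, with a stated time of 24 h; a lower number here means a stronger inhibitor, a higher number a weaker inhibitor:

compound 1, `COc1ccccc1N1CCN(CCCCCOc2c(Br)cc(Br)cc2Oc2ccc(Br)cc2Br)CC1`: 37.5 ug/mL
compound 2, `OCCOc1c(Br)cc(Br)cc1Oc1ccc(Br)cc1Br`: 34.5 ug/mL
compound 3, `CCOC(=O)C(C)Oc1c(Br)cc(Br)cc1Oc1ccc(Br)cc1Br`: 39.5 ug/mL

All three share the same brominated core and differ only in the substituent on the ether oxygen. Compound 1 stands second highest of the three numbers; its gaps to compound 3 and to compound 2 are both within the scatter, so the three read as indistinguishable. Among the measured compounds shown here, the one step measured between single-point neighbours, a 1.1-fold higher number from compound 2 to compound 3 (0.06 log units; within the scatter), is also within the scatter and concerns the ether substituent, not the ring nitrogen.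

Compound 4, `CN1CCN(CCCCCOc2c(Br)cc(Br)cc2Oc2ccc(Br)cc2Br)CC1`, is the unmeasured member. It differs from compound 1 in that (methyl in place of 2-methoxyphenyl on an amine nitrogen in a ring). For the measured compounds named here, no measured step touches the substituent on the amine nitrogen in the ring, so nothing speaks directly to this change; the only precedent is that varying the ether tail left this assay unchanged within scatter. The working expectation is therefore a step of a 1.1-fold higher number from compound 1 to compound 4 (0.03 log units; within the scatter), none beyond the scatter. Compound 4 is estimated at 40 ug/mL, with a range of 20 ug/mL to 80 ug/mL.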

Compound 4, half-maximal inhibitory concentration: 49.1 ug/mL
Compound 4: the middle estimate sits 1.2-fold (0.09 log units) below what was measured; low and high end bracket the measured number.
By their numbers in this assay, from the lowest: compounds 2, 1, 3 and 4 (each within the scatter of the next).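

In this assay, among the compounds shown here, methyl in place of 2-methoxyphenyl on the amine nitrogen in the ring gives a 1.3-fold higher number from compound 1 to compound 4 (0.12 log units; within the scatter), the first reading at this position, and it shows that the six-membered aromatic ring of that substituent is not needed to keep the number within the scatter of compound 1. The step of a 1.4-fold higher number from compound 2 to compound 4 (0.15 log units; within the scatter) shows that 3-(4-methylpiperazin-1-yl)propyl in place of hydroxy on the saturated chain carbon also stays within the scatter, so the ring amine and the hydroxy group read alike in this assay. No evidence is at hand that would account for either step.

On these data alone, whether any group on this amine nitrogen can move the number beyond the scatter remains open, for example a benzyl group, an acetyl group or a carboxylic acid on a short chain. A longer chain on the ether oxygen is equally untested by the compounds shown.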